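Cytotoxicity notes: from pyridin-4-yl to 3-methylphenyl

The compounds below may be only part of what the source reports. "The series", "measured", "known", "first", "only" and "open" are said of these compounds alone.

Compound 2 `c1ccc(Cn2cncc2CNc2cccc(-c3ccncc3)c2)cc1` gives > 1000 nM in a toxicity assay on NIH3T3 cells (Mus musculus) for cytotoxicity, read by resazurin assay (on this read-out higher numbers stand for an effect only at larger amounts of compound and lower numbers for an effect already at smaller amounts), and this is a limit of the assay and not a number. Compound 2 therefore stands at the limit of > 1000 nM in this assay, at which 1 of the 2 values shown sits. Compound 1 `COC(=O)c1ccc(NCc2cncn2Cc2ccccc2-c2ccccc2)cc1-c1ccccc1` offers no comparison, since the entry for compound 1 reads "not determined" (no result reported). Compound 3 `Cc1cccc(-c2cccc(NCc3cncn3Cc3ccccc3)c2)c1` carries 3-methylphenyl in place of pyridin-4-yl on an aromatic carbon. Within the data shown here, the series holds no step between measured compounds, so the expectation for this assay rests on the structural change and on the limit of compound 2 alone. A modest shift towards larger amounts is expected, estimated as a step that the limit leaves unreadable from compound 2 to compound 3, and a further limit rather than a number is the more likely report. For compound 3 the expected value is 3000 nM, within an estimated range of 800 nM to 20000 nM.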

Compound 3, half-maximal effective concentration: > 1000 nM
Compound 3: a limit, no number (the forecaster's own chance of this, stated with the estimate: 65%); the middle value lies beyond the limit too.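

No step can be read from compound 2 to compound 3, since both entries are limits and not numbers: the limit of > 1000 nM in this assay, at which 2 of the 3 values shown sit.

The compounds shown leave open whether 3-methylphenyl and pyridin-4-yl differ at all in cytotoxicity, and at what amount of compound either one would show an effect.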